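Ester chain lengthening in a biphenyl ester series

The source may report more compounds than this note shows. Statements on the series, on what has been measured and on what is new or still open speak of the compounds shown alone.

Measured so far:
compound 1 `CCOC(=O)c1cccc(-c2ccc(OCC)cc2)c1`, 50000 nM
compound 2 `CCOC(=O)c1cccc(-c2ccc(C(C)N(C)C)cc2)c1`, 200000 nM

Compound 1 gives the lowest of the two numbers in an assay on COS-7 cells for inhibition of patatin-like phospholipase domain-containing protein 2 (Mus musculus); a higher number here means a weaker inhibitor, a lower number a stronger inhibitor. Its nearest neighbour is compound 2, reached by the step of a 4.0-fold higher number from compound 1 to compound 2 (0.60 log units; beyond the scatter), a change at the far ring that replaces ethoxy with 1-(dimethylamino)ethyl.

Compound 3 `CCCCOC(=O)c1cccc(-c2ccc(OCC)cc2)c1` is not yet measured. It differs from compound 1 only at the ester end: ethyl in place of hydrogen on a saturated chain carbon, two bonds along the chain from an oxygen next to a carbonyl group. Going by the values given here, the one measured step, from compound 1 to compound 2, concerns the other end of the shared core and says nothing about the ester chain; no step in this set bears on the change from ethyl to butyl. Among the compounds with values here, with no precedent for the ester chain, the expectation for compound 3 in this assay is a number close to that of compound 1, a step of no change at the digits printed from compound 1 to compound 3 (within the scatter), not beyond the scatter, with a wide range allowed in either direction. The estimated value for compound 3 is 50000 nM, within 15000 nM to 170000 nM.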

Compound 3, half-maximal inhibitory concentration: 100000 nM
For compound 3 the middle estimate is 2.0-fold (0.30 log units) below the measured one; the measured number falls inside the stated range.
By their numbers in this assay, from the lowest: compounds 1, 3 and 2 (each within the scatter of the next, the first and the last beyond it).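

In this assay, the ester chain now has its first reading: ethyl in place of hydrogen on a saturated chain carbon, two bonds along the chain from an oxygen next to a carbonyl group, gives a 2.0-fold higher number from compound 1 to compound 3 (0.30 log units; within the scatter). Turning the ethyl ester of compound 1 into the butyl ester of compound 3 therefore adds two carbons with no step beyond the scatter, whereas the far-ring change gives a 4.0-fold higher number from compound 1 to compound 2 (0.60 log units; beyond the scatter), the only step here that lies beyond it. The data at hand offer no measurement that bears on the cause of this result.

A single pair within the scatter gives no direction for chain length, so it remains unclear whether a longer chain such as octyl or a branched chain such as isopropyl would stay within the scatter of compound 1. As far as these compounds go, it is equally open how the series would read with a carboxylic acid or an amide in place of the ester, and whether any such group could bring the number well below that of compound 1.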